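Trading a Cyclohexyl Ring for a Short Chain

The source may report more compounds than this note shows. Statements on the series, on what has been measured and on what is new or still open speak of the compounds shown alone.

Among the compounds with values here, in a functional assay on HCT-116 cells (Homo sapiens) for inhibition, with a stated time of 72 h (on this read-out lower numbers stand for stronger inhibition and higher numbers for weaker inhibition), compound 3 `OC1CCC(Nc2nc(NCc3ccc(-c4ccco4)nc3)c3ncn(C4CCCC4)c3n2)CC1` gives 617 nM, the middle of the three numbers known so far. Compound 2 `NC1CCC(Nc2nc(NCc3ccc(-c4ccco4)nc3)c3ncn(C4CCCC4)c3n2)CC1` lies lower at 86 nM, and compound 1 `CC(C)(O)CNc1nc(NCc2ccc(-c3ccco3)cc2)c2ncn(C3CCCC3)c2n1` lies much higher at 16700 nM.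

Compound 4 `CC(C)(O)CNc1nc(NCc2ccc(-c3ccco3)nc2)c2ncn(C3CCCC3)c2n1` has not yet been measured. It differs from compound 3 in one place: 2-hydroxy-2-methylpropyl in place of 4-hydroxycyclohexyl on a nitrogen on an aromatic ring. In plain terms, 2-hydroxy-2-methylpropyl takes the place of 4-hydroxycyclohexyl on a nitrogen on an aromatic ring.

Within the data shown here, only one measured step touches this part of the structure: a 7.2-fold higher number from compound 2 to compound 3 (0.86 log units; beyond the scatter). That step replaces amino with hydroxy on the saturated ring, so it shows that a change at this group can shift the number beyond the scatter. It does not test the new chain, however.

The closer clue is that compound 1 already carries 2-hydroxy-2-methylpropyl. It differs from compound 4 elsewhere in the structure, so the value of compound 1 at 16700 nM is only a rough guide. That value still points towards a weaker result, and a rise beyond the scatter is expected in this assay, an estimated 4.9-fold higher number from compound 3 to compound 4 (0.69 log units; beyond the scatter).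

The estimate for compound 4 is 3000 nM, with an expected range from 700 nM to 13000 nM.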

Compound 4, half-maximal inhibitory concentration: 1270 nM
Compound 4: the middle estimate sits 2.4-fold (0.37 log units) above what was measured; the range from low to high includes it.
By their numbers in this assay, from the lowest: compound 2; then compound 3; then compound 4; then compound 1.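

Within this assay, swapping the ring for the open chain changes little: 2-hydroxy-2-methylpropyl in place of 4-hydroxycyclohexyl gives a 2.1-fold higher number from compound 3 to compound 4 (0.31 log units; beyond the scatter) and keeps the hydroxy group, so the number moves only modestly even though the ring is gone. The same chain measured against 4-aminocyclohexyl gives a large step (a 15-fold higher number from compound 2 to compound 4 (1.17 log units; beyond the scatter)), which leaves the amino-bearing ring of compound 2 clearly ahead of this short chain. With the chain held constant, 6-(furan-2-yl)pyridin-3-yl in place of 4-(furan-2-yl)phenyl gives a 13-fold lower number from compound 1 to compound 4 (1.12 log units; beyond the scatter), so the very high number of compound 1 goes with its other aryl group and not with the chain alone.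

Still open, as far as these compounds go, is whether an amine on the short chain, or a longer chain carrying an amine, would bring a gain like the one seen on the ring, where hydroxy in place of amino gives a 7.2-fold higher number from compound 2 to compound 3 (0.86 log units; beyond the scatter). Nothing available here explains why any of these changes shifts the number as it does.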